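Swapping the Side Ring of Compound 3 for a Triazole

A few compounds are considered here, and "the series" means these few. Any claim that something is new, unique, unknown or untested is made for them only; others in the source may bear on it.

Of the compounds shown here, three sharing one core have been measured in a physicochemical assay for solubility, read by HPLC, using the shake flask method, measured as kinetic solubility, with a stated time of 2 h, at pH 7.4; a lower number here means a less soluble compound, a higher number a more soluble compound. Compound 1 `Cc1cc(NCc2ccncc2)n2nc(C)c(-c3ccccc3)c2n1` gives 134000 nM. Compound 2 `Cc1cc(NCc2ncccn2)n2nc(C)c(-c3ccccc3)c2n1` gives 37900 nM. Compound 3 `CCN1CCCC1CNc1cc(C)nc2c(-c3ccccc3)c(C)nn12` gives 172000 nM, which is the highest number of the three, although its gap to compound 1 is within the scatter, while its gap to compound 2 is beyond it. The measured steps show a 3.5-fold lower number from compound 1 to compound 2 (0.55 log units; beyond the scatter), a 1.3-fold higher number from compound 1 to compound 3 (0.11 log units; within the scatter) and a 4.5-fold higher number from compound 2 to compound 3 (0.66 log units; beyond the scatter).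

Compound 4 `Cc1cc(NCc2ncnn2C)n2nc(C)c(-c3ccccc3)c2n1` has not yet been measured in this assay. It differs from compound 3 in one place: 1-methyl-1H-1,2,4-triazol-5-yl in place of 1-ethylpyrrolidin-2-yl on a saturated chain carbon bound to a nitrogen on an aromatic ring. Within the data shown here, the steps that bear on this change are the two that exchange the pyrrolidine side ring for a six-membered aromatic ring with nitrogen atoms, namely the step from compound 3 back to compound 1, which stayed within the scatter, and the step from compound 3 back to compound 2, which was a modest drop. Since the incoming triazole is, like pyrimidine, an aromatic ring holding several nitrogen atoms, a modest fall beyond the scatter is expected rather than no change. Compound 4 is therefore expected to give about 55000 nM, within a range from 20000 nM to 150000 nM, an estimated step of a 3.1-fold lower number from compound 3 to compound 4 (0.50 log units; beyond the scatter).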

Compound 4, solubility: 185000 nM
Compound 4: middle estimate off by 3.4-fold (0.53 log units), on the low side; measured number above the stated range.
By their numbers in this assay, from the lowest: compound 2; then compounds 1, 3 and 4 (each within the scatter of the next).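

At this position, on a saturated chain carbon bound to a nitrogen on an aromatic ring, 1-methyl-1H-1,2,4-triazol-5-yl can replace a non-aromatic ring with no clear change in this assay, the step being a 1.1-fold higher number from compound 3 to compound 4 (0.03 log units; within the scatter). It also stands level with pyridin-4-yl, with a 1.4-fold higher number from compound 1 to compound 4 (0.14 log units; within the scatter), so three quite different side rings now give numbers within the scatter of one another. Among these compounds, the earlier compounds left pyrimidin-2-yl as the only example of an aromatic ring with several nitrogen atoms, and that example was low; the triazole, also aromatic and rich in nitrogen, does not share that result, as a 4.9-fold higher number from compound 2 to compound 4 (0.69 log units; beyond the scatter) shows, so compound 2 alone stands apart among the four.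

Nothing shown here explains why pyrimidin-2-yl alone gives the lower number. The compounds also leave open whether the level result would hold for a triazole without its methyl, for an open-chain amine such as a dimethylaminoethyl group in the same place, or for a carboxylic acid there.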